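A few compounds are considered here, and "the series" means these few. Any claim that something is new, unique, unknown or untested is made for them only; others in the source may bear on it.

Measured in a functional assay on SMMC-7721 cells (Homo sapiens) for antiproliferative activity, read by MTT assay, with a stated time of 72 h; on this read-out lower numbers stand for stronger inhibition and higher numbers for weaker inhibition:
compound 1 `CCC(=O)N(C)c1ccc2[nH]c(-c3n[nH]c4ccccc34)cc2n1` gives 33500 nM
compound 2 `CN(C(=O)c1ccc(Br)cc1)c1ccc2[nH]c(-c3n[nH]c4ccccc34)cc2n1` gives 3460 nM
compound 3 `CN(c1ccc2[nH]c(-c3n[nH]c4ccccc34)cc2n1)S(=O)(=O)c1ccccc1` gives 12000 nM

Compound 3 stands second highest of the three numbers in this assay: a 2.8-fold lower number from compound 1 to compound 3 (0.45 log units; beyond the scatter) and a 3.5-fold higher number from compound 2 to compound 3 (0.54 log units; beyond the scatter). Compound 4 `CN(c1ccc2[nH]c(-c3n[nH]c4ccccc34)cc2n1)S(=O)(=O)c1ccc(Br)cc1` differs from compound 3 by bromo in place of hydrogen on an aromatic carbon. For the measured compounds named here, no measured step isolates this change. The nearest is a 9.7-fold lower number from compound 1 to compound 2 (0.99 log units; beyond the scatter), but it bundles the bromo with an aryl-for-alkyl swap on a carbonyl, so only part of it can be credited to the bromo. A modest lowering of the number is therefore expected for compound 4 in this assay, likely near the edge of the scatter, as a 2.0-fold lower number from compound 3 to compound 4 (0.30 log units; within the scatter). Compound 4 is estimated at 6000 nM in this assay, within 2500 nM to 15000 nM.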

Compound 4, half-maximal inhibitory concentration: 11500 nM
For compound 4 the middle estimate is 1.9-fold (0.28 log units) below the measured one; measured number inside the range.
By their numbers in this assay, from the lowest: compound 2; then compounds 4 and 3 (each within the scatter of the next); then compound 1.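

In this assay there is a 1.0-fold lower number from compound 3 to compound 4 (0.02 log units; within the scatter) for bromo in place of hydrogen, so on the phenylsulfonyl group this position shows no change beyond the scatter. The link carrying the ring still counts: there is a 3.3-fold higher number from compound 2 to compound 4 (0.52 log units; beyond the scatter) for (4-bromophenyl)sulfonyl in place of (4-bromophenyl)carbonyl, and a 2.9-fold lower number from compound 1 to compound 4 (0.46 log units; beyond the scatter) for the same sulfonyl group in place of propanoyl. Nothing available explains these results. As far as these compounds go, whether bromo counts on the phenyl ring of the carbonyl compounds remains open. So does whether a methoxy group or an amine at this position would move the number.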